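A few compounds are considered here, and "the series" means these few. Any claim that something is new, unique, unknown or untested is made for them only; others in the source may bear on it.

In a functional assay on MCF7 cells (Homo sapiens) for inhibition, read by CCK-8 assay, with a stated time of 48 h (a lower number here means a stronger inhibitor, a higher number a weaker inhibitor), compound 2 `COc1cc(-c2ccnc3cc(-c4ccccc4)nn23)cc(OC)c1OC` gives 254 nM. Of the two compounds that return a number in this assay, compound 2 has the higher one; compound 3 `COc1cc(-c2ccnc3cc(-c4ccc5c(ccn5C)c4)nn23)cc(OC)c1OC` gives 3 nM. Compound 1 `COc1cc(-c2cc3nccc(-c4c[nH]c5ccccc45)n3n2)cc(OC)c1OC` sits at a limit of this assay, > 10000 nM, so no number is known for it. For the measured compounds named here, the only step that can be weighed is an 85-fold lower number from compound 2 to compound 3 (1.93 log units; beyond the scatter), a change in which 1-methyl-1H-indol-5-yl, a much larger group, takes the place of phenyl.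

Compound 4 `COc1cc(-c2ccnc3cc(-c4ccc(C(C)(C)C)cc4)nn23)cc(OC)c1OC` has not yet been measured in this assay. It differs from compound 2 by tert-butyl in place of hydrogen on an aromatic carbon. Going by the values given here, this change keeps the phenyl and adds a group that carries no ring, so it is a different kind of alteration from the one between compound 2 and compound 3, and that step cannot simply be carried over. All the numbers show is that a larger group at this end of the shared core did not weaken the inhibitor. On that basis a modest gain is expected, with wide uncertainty, as a 2.1-fold lower number from compound 2 to compound 4 (0.33 log units; beyond the scatter). Compound 4 is therefore estimated at 120 nM, with a range from 20 nM to 800 nM.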

Compound 4, half-maximal inhibitory concentration: > 10000 nM
Compound 4 gave a limit, no number; the forecaster's own chance of this, stated with the estimate: 5%; at least 83-fold (1.92 log units) between middle value and limit.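

In this assay, putting tert-butyl on the phenyl ring, para to a large group, brings a heavy loss rather than a gain: an at least 39-fold higher number from compound 2 to compound 4 (1.59 log units; beyond the scatter). The contrast with the other large group at this end of the shared core is wider still, an at least 3300-fold higher number from compound 3 to compound 4 (3.52 log units; beyond the scatter), so among these compounds a larger group does not by itself give the strength seen with 1-methyl-1H-indol-5-yl. The value of compound 4, > 10000 nM, is a limit and not a number, so both steps give only a minimum size: the limit of > 10000 nM in this assay, at which 2 of the 4 values shown sit.

From the compounds shown here alone, it remains open whether this loss belongs to tert-butyl alone or to almost any group at this place on the phenyl ring, a question that a smaller methyl, a methoxy or an amine at the same spot could help to settle. It is also unclear which part of 1-methyl-1H-indol-5-yl carries the gain, since a comparison with the same indole lacking its methyl group is not among these compounds, and compound 1 differs from the others in more than one place.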